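The source may report more compounds than this note shows. Statements on the series, on what has been measured and on what is new or still open speak of the compounds shown alone.

Compound 1 (`Cc1cc(C)c2cc(C(=O)NC3CCCCC3)[nH]c2c1`) is the starting point, and its partner compound 2 (`Cc1cc(C)c2cc(C(=O)NC3CCN(C(C)C)CC3)[nH]c2c1`) shares the same core but adds nothing to the comparison. In an ADME assay on Vero cells (Chlorocebus sabaeus) for cytotoxicity, read by resazurin assay (on this read-out higher numbers stand for weaker inhibition and lower numbers for stronger inhibition), compound 1 gives > 200000 nM, which is a limit of the assay and not a number. For compound 2, the entry reads "not determined" (no result reported). Compound 3 (`Cc1cc(C)c2cc(C(=O)NC3CCCCCC3)[nH]c2c1`) keeps the core of compound 1 and carries cycloheptyl in place of cyclohexyl on an amide-type nitrogen. Among the measured compounds shown here, no measured step shows what such a swap does here, so the expectation rests on compound 1 alone, at > 200000 nM. The change is expected to stay within the usual scatter, and compound 3 may well be reported as a limit too. The estimated move is a number no higher from compound 1 to compound 3 (the limit leaves the size open). For compound 3, the expected value in this assay is 200000 nM, with an estimated range from 90000 nM to 400000 nM.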

Compound 3, half-maximal inhibitory concentration: > 200000 nM
Compound 3 ended at the assay's limit; the forecaster's own chance of this, stated with the estimate: 70%; the middle value sits exactly at the limit.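

No step can be read from compound 1 to compound 3, since both values are limits of the assay and not numbers: the limit of > 200000 nM in this assay, at which 2 of the 3 values shown sit. In this assay the compounds shown leave open what cycloheptyl in place of cyclohexyl on an amide-type nitrogen does to the value.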